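Swapping Propyl for Oxolan-3-yl on a Pyrazole Nitrogen

A few compounds are considered here, and "the series" means these few. Any claim that something is new, unique, unknown or untested is made for them only; others in the source may bear on it.

Measured compounds:
compound 1 `Cc1ccc(C(=O)Nc2cccc(C(F)(F)F)c2)cc1-c1ccc2c(-c3ccc(N4CCN(C)CC4)cc3)n[nH]c2c1`: 8.8 nM
compound 2 `CCCn1cc(-c2n[nH]c3cc(-c4cc(C(=O)Nc5cccc(C(F)(F)F)c5)ccc4C)ccc23)cn1`: 3.2 nM

Both compounds were tested in an assay on isolated protein for inhibition of Discoidin domain-containing receptor 2 (Homo sapiens), read by ELISA, with a stated time of 60 min; on this read-out lower numbers stand for stronger inhibition and higher numbers for weaker inhibition. In this assay compound 1 gives 8.8 nM, while compound 2 gives 3.2 nM. Compound 2 therefore holds the lowest of the two numbers; its nearest neighbour is compound 1, whose number is higher by a gap that lies beyond the usual scatter of repeated runs.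

Compound 3 `Cc1ccc(C(=O)Nc2cccc(C(F)(F)F)c2)cc1-c1ccc2c(-c3cnn(C4CCOC4)c3)n[nH]c2c1` is not yet measured. It differs from compound 2 in one place only: oxolan-3-yl in place of propyl on an aromatic nitrogen. In words, oxolan-3-yl takes the place of propyl on an aromatic nitrogen.

Within the data shown here, no pair of measured compounds shows this kind of exchange, so there is no measured step to rest a direction on. The two groups are of similar size, and the change is expected to shift the number by at most an amount within the scatter, which the step of a 1.4-fold higher number from compound 2 to compound 3 (0.15 log units; within the scatter) reflects. Compound 3 is thus estimated at 4.5 nM, within a range from 1.5 nM to 14 nM.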

Compound 3, half-maximal inhibitory concentration: 6.2 nM
Compound 3: middle estimate off by 1.4-fold (0.14 log units), on the low side; measured number inside the range.
By their numbers in this assay, from the lowest: compounds 2, 3 and 1 (each within the scatter of the next, the first and the last beyond it).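

In this assay, among these compounds, this is the first direct reading of a change at this position: a 1.9-fold higher number from compound 2 to compound 3 (0.29 log units; within the scatter) shows that oxolan-3-yl can take the place of propyl on an aromatic nitrogen without a difference that can be told from the scatter. This holds even though the two groups are not alike on paper: oxolan-3-yl brings a five-membered non-aromatic ring and 1 hydrogen-bond acceptor, while propyl has no ring and no acceptor, so for this one pair neither feature separates the two numbers. No measured evidence bears on why the two compounds read alike, so the step describes the numbers and gives no explanation for them.

The compounds shown leave open how much this position will accept, for instance whether a longer chain such as hexyl, an amine such as piperidin-4-yl or a carboxylic acid on the same nitrogen would stay within the scatter of compound 2 or move beyond it. They also leave open what cyclopentyl would give, a ring of the same size without the oxygen, which would help separate the ring from the oxygen.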